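Notes on the step from ethyl to 4-bromobenzyl

The source may report more compounds than this note shows. Statements on the series, on what has been measured and on what is new or still open speak of the compounds shown alone.

compound 1 `O=C1N(Cc2ccc(Br)cc2)c2ccc(F)cc2C1(O)Cc1nnn[nH]1`: > 100000 nM (a limit)
compound 2 `CN1C(=O)C(O)(Cc2nnn[nH]2)c2cc(Cl)ccc21`: > 100000 nM (a limit)
compound 3 `CCN1C(=O)C(O)(Cc2nnn[nH]2)c2cc(Cl)ccc21`: 85400 nM
compound 4 `O=C1N(Cc2ccc(Br)cc2)c2ccc(Cl)cc2C1(O)Cc1nnn[nH]1`: not yet measured

For the measured compounds named here, in a functional assay on BT-549 cells (Homo sapiens) for antiproliferative activity, read by MTT assay, with a stated time of 48 h (on this read-out higher numbers stand for weaker inhibition and lower numbers for stronger inhibition), compound 3 gives 85400 nM, the only actual number in the set. The other entries stand at the limit of > 100000 nM in this assay, at which 2 of the 3 values shown sit.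

Compound 4 is reached from compound 3 by one change: 4-bromophenyl in place of methyl on a saturated chain carbon bound to an amide-type nitrogen in a ring. In words, this is 4-bromophenyl in place of methyl on a saturated chain carbon bound to an amide-type nitrogen in a ring. Cut one bond further out, it reads ethyl to 4-bromobenzyl.

Going by the values given here, one measured step touches this place: an at least 1.1-fold lower number from compound 2 to compound 3 (0.06 log units; that floor lies within the scatter). Its floor lies within the scatter, so it sets no direction for a much larger group. Compound 1 carries the same 4-bromobenzyl group and reports > 100000 nM, which is a limit. On that evidence, no step beyond the scatter is expected in this assay, and a result at the limit remains a real possibility.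

The expected change is a 1.2-fold lower number from compound 3 to compound 4 (0.09 log units; within the scatter). For compound 4 the estimated value is 70000 nM, with an expected range of 25000 nM to 140000 nM.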

Compound 4, half-maximal inhibitory concentration: 74500 nM
For compound 4 the middle estimate is 1.1-fold (0.03 log units) below the measured one, and the stated range covers the measured number.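

In this assay, the exchange of methyl for 4-bromophenyl on a saturated chain carbon bound to an amide-type nitrogen in a ring gives a 1.1-fold lower number from compound 3 to compound 4 (0.06 log units; within the scatter), so this much larger group with its aromatic ring leaves the read-out within the scatter of the ethyl compound. The other two steps, an at least 1.3-fold lower number from compound 2 to compound 4 (0.12 log units; that floor lies within the scatter) and an at least 1.3-fold lower number from compound 1 to compound 4 (0.12 log units; that floor lies within the scatter), have floors within the scatter, so neither 4-bromophenyl in place of hydrogen at this position nor chloro in place of fluoro on an aromatic carbon can be given a direction or a size. Both of these steps start from a limit, not a number: the limit of > 100000 nM in this assay, at which 2 of the 4 values shown sit.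

Still open, going by these compounds, is whether a longer chain such as propyl, an unsubstituted benzyl, or an amine or a carboxylic acid in place of the bromine of 4-bromobenzyl would move the number beyond the scatter at this position. With every readable step here inside the scatter or bounded only by a floor within it, the compounds shown give no direction for this position or for the halogen on the aromatic carbon.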